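The source may report more compounds than this note shows. Statements on the series, on what has been measured and on what is new or still open speak of the compounds shown alone.

Measured in an ADME assay on HEK-293T cells (Homo sapiens) for cytotoxicity, read by CCK-8 assay, with a stated time of 48 h; a lower number here means a stronger inhibitor, a higher number a weaker inhibitor:
- Compound 1 `O=C(NCCNS(=O)(=O)c1ccc(-c2ccccc2OCc2cccc(O)c2)s1)Nc1cc(C(F)(F)F)cc(C(F)(F)F)c1`: > 20000 nM (a limit)
- Compound 2 `O=S(=O)(NCCNC(=S)Nc1cc(C(F)(F)F)cc(C(F)(F)F)c1)c1ccc(-c2ccccc2O[C@H]2CC[C@@H](O)CC2)s1`: > 20000 nM (a limit)
- Compound 3 `COc1ccc(Oc2ccc([N+](=O)[O-])cc2-c2ccsc2S(=O)(=O)N2CCN(C(=O)Nc3ccc([N+](=O)[O-])cc3)CC2)cc1OC`: > 20000 nM (a limit)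

Compound 2 has no number on this read-out, only the limit > 20000 nM. It shares this position with the other two compounds: the limit of > 20000 nM in this assay, at which 3 of the 3 values shown sit.

Compound 4 `O=[N+]([O-])c1ccc(Oc2ccccc2-c2ccc(S(=O)(=O)NCCNC(=S)Nc3cc(C(F)(F)F)cc(C(F)(F)F)c3)s2)cc1` has 4-nitrophenyl in place of 4-hydroxycyclohexyl on an oxygen on an aromatic ring.

Compound 3 also carries a 4-nitrophenyl group, and it too gives only a limit, > 20000 nM. No change beyond the scatter is therefore expected in this assay. The expected size of the change is a number no higher from compound 2 to compound 4 (the limit leaves the size open). Compound 4 is estimated at 20000 nM. The expected range for compound 4 is 9000 nM to 40000 nM.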

Compound 4, half-maximal inhibitory concentration: 6000 nM
Estimate against measurement, compound 4: 3.3-fold (0.52 log units) above; the whole stated range lies above it.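

In this assay, the group on this oxygen turns out to matter: 4-nitrophenyl in place of 4-hydroxycyclohexyl gives an at least 3.3-fold lower number from compound 2 to compound 4 (0.52 log units; beyond the scatter). From the compounds shown here alone, compound 2 stands at a limit, so this step is a minimum and its full size stays open. Compound 4 is the only compound shown with a number rather than a limit: the limit of > 20000 nM in this assay, at which 3 of the 4 values shown sit.

Open, going by these compounds, is whether the aromatic ring or the nitro group accounts for the step. Unsubstituted phenyl, 4-aminophenyl or 4-carboxyphenyl on the same oxygen would separate the two.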